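Dichloroquinolinyl versus methylquinolinyl ethers: cytotoxicity on SNB-19 cells

This account rests on a few compounds, and the source may have more. Where it says the series, first, only, none or still open, it means among the compounds named here.

Two members of the series have been measured. Compound 1 `C=C1CC[C@@H]2[C@](C)(COC(C)=O)[C@H](O)CC[C@@]2(C)[C@@H]1C/C=C1/C(=O)OC[C@@H]1Oc1c(Cl)cc(Cl)c2cccnc12` gives 39300 nM in an ADME assay on SNB-19 cells (Homo sapiens) for cytotoxicity, read by MTT assay, with a stated time of 24 h; a lower number here means that less compound is tolerated, a higher number that more compound is tolerated. For compound 2 `C=C1CC[C@@H]2[C@](C)(COC(C)=O)[C@H](O)CC[C@@]2(C)[C@@H]1C/C=C1/C(=O)OC[C@H]1Oc1cccc2ccc(C)nc12` this assay reports only a limit, > 100000 nM, so compound 2 stands at the top of the range seen so far and its true value is not known as a number. Going by the values given here, no pair of measured compounds differs in a single place, so no measured step is available; the only evidence is the limit of > 100000 nM in this assay, at which 1 of the 2 values shown sits.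

Compound 3 `C=C1CC[C@@H]2[C@](C)(COC(C)=O)[C@H](O)CC[C@@]2(C)[C@@H]1C/C=C1/C(=O)OC[C@H]1Oc1c(Cl)cc(Cl)c2cccnc12` is not yet measured. It differs from compound 2 by 5,7-dichloroquinolin-8-yl in place of 2-methylquinolin-8-yl on an oxygen on a saturated carbon. Compound 2 is known only as a limit, so the step in this assay cannot be sized against a measured pair. A move toward a lower tolerated concentration is expected, with the size taken from where compound 1 sits at 39300 nM. Compound 3 is therefore estimated at 45000 nM, within 15000 nM to 150000 nM, the expected step being an at least 2.2-fold lower number from compound 2 to compound 3 (0.34 log units; beyond the scatter).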

Compound 3, half-maximal cytotoxic concentration: 88700 nM
For compound 3 the middle estimate is 2.0-fold (0.29 log units) below the measured one, and the stated range covers the measured number.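

In this assay, the exchange of 2-methylquinolin-8-yl for 5,7-dichloroquinolin-8-yl on an oxygen on a saturated carbon gives an at least 1.1-fold lower number from compound 2 to compound 3 (0.05 log units; that floor lies within the scatter), so this exchange is not shown to move the number beyond the scatter, and its true size stays unread because compound 2 is held only as a limit: the limit of > 100000 nM in this assay, at which 1 of the 3 values shown sits.

The series now also has its first step at the saturated ring carbon with the group on the oxygen held constant: going from the R to the S drawing gives a 2.3-fold higher number from compound 1 to compound 3 (0.35 log units; beyond the scatter), a modest change that can be assigned to the drawn configuration alone: the fact that compounds 1 and 3 differ only in the configuration as drawn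

Going by these compounds alone, at this position, then, the one sized step comes from the stereocentre and not from the exchange of quinolinyl groups.

Whether the configuration step carries over to the 2-methylquinolin-8-yl ether remains open, since the compounds shown give that step for 5,7-dichloroquinolin-8-yl only. Also open, from the compounds shown here alone, is how a group outside the quinolinyl ethers, such as a simple benzyl or a chain ending in an amine, would read on the same oxygen in this assay.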